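From benzyloxy to hydroxy on an aromatic ring

The compounds below may be only part of what the source reports. "The series", "measured", "known", "first", "only" and "open" are said of these compounds alone.

Compound 1 `COc1cc(OC)c2cc(-c3ccccc3)c(O)nc2c1` measured at 10000 nM
Compound 2 `COc1cc(OC)c2cc(-c3ccc(OCc4ccccc4)cc3)c(O)nc2c1` measured at 10000 nM

Both values come from a functional assay on PC-3 cells (Homo sapiens) for cytotoxicity, read by colorimetric assay and MTT assay (a higher number here means a weaker inhibitor, a lower number a stronger inhibitor), and compound 2 stands level with compound 1 there, so neither is ahead of the other. Among the measured compounds shown here, the only measured step is no change at the digits printed from compound 1 to compound 2 (within the scatter) and it came from putting benzyloxy in place of hydrogen on an aromatic carbon.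

Compound 3 `COc1cc(OC)c2cc(-c3ccc(O)cc3)c(O)nc2c1` has not been measured yet. It differs from compound 2 by one change: hydrogen in place of benzyl on an oxygen on an aromatic ring (hydrogen in place of benzyl on an oxygen on an aromatic ring, or benzyloxy to hydroxy). The measured step added benzyloxy and this change cuts it back to hydroxy, so both concern the same group. For the measured compounds named here, no measured compound carries hydroxy, however, which leaves the evidence thin.

The result no change at the digits printed from compound 1 to compound 2 (within the scatter) gives no ground for predicting a shift beyond the scatter, in either direction. The expected step in this assay is therefore no change at the digits printed from compound 2 to compound 3 (within the scatter) with no clear direction. Compound 3 is estimated at 10000 nM (expected range 3000 nM to 15000 nM) on this single step.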

Compound 3, half-maximal inhibitory concentration: 10000 nM
Estimate against measurement, compound 3: no gap at the digits printed; the range from low to high includes it.
By their numbers in this assay, from the lowest: compounds 1, 2 and 3 (each within the scatter of the next).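

In this assay, taking the benzyl off the oxygen on the aromatic ring gives no change at the digits printed from compound 2 to compound 3 (within the scatter) even though a whole six-membered aromatic ring of carbon leaves with it, so the size of this group makes no visible difference between benzyloxy and hydroxy in these compounds. Hydroxy in place of hydrogen on the aromatic carbon gives no change at the digits printed from compound 1 to compound 3 (within the scatter) and this adds a third group to the comparison: hydrogen, benzyloxy and hydroxy now all read alike at this one place, which a single pair could not show. Nothing measured here explains why the three values stay together.

As far as these compounds go, three groups at one place are a narrow sample, so it remains open whether an amine or a carboxylic acid on that same aromatic carbon would move the value in this assay at all. Since all three compounds read alike, they also leave open whether a change elsewhere on the shared core, such as replacing one of the methoxy groups with a longer chain, would matter more than any change at this place.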